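Working notes: amino in place of bromo in compound 2

This account rests on a few compounds, and the source may have more. Where it says the series, first, only, none or still open, it means among the compounds named here.

Compound 1 (`O=C(O)c1ccc(C(=O)/C(=C\c2ccc(Br)c([N+](=O)[O-])c2)SCc2ccc(Cl)cc2)cc1`): < 1000 nM (a limit)
Compound 2 (`O=C(O)c1ccc(C(=O)/C(=C\c2ccc(Br)c([N+](=O)[O-])c2)SCc2ccc(F)cc2)cc1`): 1000 nM

Going by the values given here, in a functional assay on DU-145 cells (Homo sapiens) for inhibition, read by trypan blue exclusion, with a stated time of 96 h (on this read-out lower numbers stand for stronger inhibition of growth and higher numbers for weaker inhibition of growth), compound 2 gives 1000 nM as the only actual number so far. Compound 1 is held only by a limit, (the limit of < 1000 nM in this assay, at which 1 of the 2 values shown sits), and not by a number. Among the compounds with values here, the one measured step, a number no lower from compound 1 to compound 2 (the limit leaves the size open), is fluoro in place of chloro, a different change, and offers no size to carry over. Compound 3 (`Nc1ccc(/C=C(/SCc2ccc(F)cc2)C(=O)c2ccc(C(=O)O)cc2)cc1[N+](=O)[O-]`) differs from compound 2 by amino in place of bromo on an aromatic carbon, that is, 4-bromo-3-nitrophenyl to 4-amino-3-nitrophenyl. With no measured guide, no shift beyond the scatter is expected, and the estimated step is a 1.3-fold higher number from compound 2 to compound 3 (0.11 log units; within the scatter) here. For compound 3 the expected value in this assay is 1300 nM, with an estimated range of 350 nM to 5000 nM here.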

Compound 3, concentration for 50% growth inhibition: 10000 nM
For compound 3 the middle estimate is 7.7-fold (0.89 log units) below the measured one, outside the stated range (above it).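

Going by these compounds alone, on an aromatic carbon ortho to the nitro group, amino in place of bromo gives a 10-fold higher number from compound 2 to compound 3 (1.00 log units; beyond the scatter) in this assay, so this position responds to the change, and this is the first step with a readable size. Bromo is the better of these two groups here. No measurement shown gives a reason for the shift.

From the compounds shown here alone, it remains open whether a hydroxyl, a methoxy or a dimethylamino group at this position would track bromo or amino. Going by these compounds, the same change on compound 1, with its chloro group, also remains open.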